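This account rests on a few compounds, and the source may have more. Where it says the series, first, only, none or still open, it means among the compounds named here.

Working notes on the series. Three measured compounds share one core and differ only in the group sitting on a saturated chain carbon bound to an oxygen next to a carbonyl group. Compound 1 `CCOc1cc(NC(=O)C2(NC(=O)c3ccc4c(C5CCCC5)c(-c5ncc(Cl)cn5)n(C)c4c3)CCC2)ccc1/C=C/C(=O)OCOP(=O)(O)OC(C)(C)C` carries a phosphorus-containing group there; in an ADME assay (liver) for pharmacokinetics, with Liver microsome (Rattus norvegicus) as the target, using microsomes (on this read-out higher numbers stand for a longer-lived compound and lower numbers for a shorter-lived compound), compound 1 gives 0.133 h, the lowest of the three numbers. Compound 2 `CCOc1cc(NC(=O)C2(NC(=O)c3ccc4c(C5CCCC5)c(-c5ncc(Cl)cn5)n(C)c4c3)CCC2)ccc1/C=C/C(=O)OCC(C)C` gives 1.42 h in this assay, and compound 3 `CCOc1cc(NC(=O)C2(NC(=O)c3ccc4c(C5CCCC5)c(-c5ncc(Cl)cn5)n(C)c4c3)CCC2)ccc1/C=C/C(=O)OCCOCCOC` gives 1.07 h in this assay. Both measured steps away from compound 1 run upward: an 11-fold higher number from compound 1 to compound 2 (1.03 log units; beyond the scatter) and an 8.0-fold higher number from compound 1 to compound 3 (0.91 log units; beyond the scatter). Between the two replacements the step is a 1.3-fold lower number from compound 2 to compound 3 (0.12 log units; within the scatter), so they are not told apart.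

Compound 4 `CCOc1cc(NC(=O)C2(NC(=O)c3ccc4c(C5CCCC5)c(-c5ncc(Cl)cn5)n(C)c4c3)CCC2)ccc1/C=C/C(=O)OCC(=O)OCc1ccc(Cl)cc1` makes the change (a group of 11 heavy atoms (8 carbon, 2 oxygen, 1 chlorine; one six-membered aromatic ring of carbon only) in place of a group of 9 heavy atoms (4 carbon, 4 oxygen, 1 phosphorus; no ring), on a saturated chain carbon bound to an oxygen next to a carbonyl group). Within the data shown here, the steps that bear on it are the two leaving from compound 1, since in each the phosphorus-containing group is removed and the number rises beyond the scatter, as in an 11-fold higher number from compound 1 to compound 2 (1.03 log units; beyond the scatter) and an 8.0-fold higher number from compound 1 to compound 3 (0.91 log units; beyond the scatter). The entering ((4-chlorobenzyl)oxy)carbonyl, with its six-membered aromatic ring, resembles neither measured replacement, so the size is less certain than the direction. For compound 4 in this assay an upward step of a 6.0-fold higher number from compound 1 to compound 4 (0.78 log units; beyond the scatter) is expected. The estimate for compound 4 is therefore 0.8 h, with a range from 0.3 h to 2 h.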

Compound 4, half-life: 11.4 h
Beside the measured number, compound 4's estimate is 14-fold (1.15 log units) below it; measured number above the stated range.
By their numbers in this assay, from the lowest: compound 1; then compounds 3 and 2 (each within the scatter of the next); then compound 4.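

In this assay the ((4-chlorobenzyl)oxy)carbonyl group sets compound 4 clear of all three earlier compounds, with an 86-fold higher number from compound 1 to compound 4 (1.93 log units; beyond the scatter) and an 11-fold higher number from compound 3 to compound 4 (1.03 log units; beyond the scatter) and also an 8.0-fold higher number from compound 2 to compound 4 (0.90 log units; beyond the scatter) as the steps that place it. The earlier compounds shown here showed only two levels at this place on a saturated chain carbon bound to an oxygen next to a carbonyl group, with compound 1 low and compounds 2 and 3 not told apart; compound 4 adds a third, higher level, so the number here is not settled merely by removing the phosphorus-containing group. No measurement shown gives a cause for this rise.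

The compounds shown leave open whether the chlorine, the six-membered aromatic ring or the carbonyl of the entering group accounts for the rise, for all three enter together in compound 4. The same group without its chlorine, a fluorine in the chlorine's place, or a chain ending in an amine or a carboxylic acid would be needed to separate these parts.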